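Nitro in Place of Hydroxy: Paw Edema Outlook

The source may report more compounds than this note shows. Statements on the series, on what has been measured and on what is new or still open speak of the compounds shown alone.

Measured compounds:
compound 1 `C/C(=N\OCC(=O)O)c1ccccc1O` — < 20%
compound 2 `C/C(=N\OCC(=O)O)c1ccc(O)cc1` — < 20%

In a functional assay on the whole organism for inhibition, with Rattus norvegicus as the target, read by paw edema, with stated times of 1 h and 3 h, at a dose of 50 mg/kg by the oral route (a lower number here means less inhibition, a higher number more inhibition at the dose given (going by the name of the read-out)), compound 1 gives < 20%, which is a limit of the assay rather than a number. Compound 2 gives < 20%, likewise a limit. Both values share the same limit (the limit of < 20% in this assay, at which 2 of the 2 values shown sit), so compound 2 stands at the floor of what the assay reports. Compound 3 `C/C(=N\OCC(=O)O)c1ccc([N+](=O)[O-])cc1` differs from compound 2 in one place: nitro in place of hydroxy on an aromatic carbon. Going by the values given here, no measured step shows how such a change acts here, so the step that the limit leaves unreadable from compound 2 to compound 3 is expected to be none beyond the scatter. Compound 3 is estimated at 15%, within 0% to 35%, quite possibly reported again only as a limit.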

Compound 3, a percentage reported as inhibition, in the whole organism at one dose (the size of the read-out at that dose, not a potency): < 20%
Compound 3 ended at the assay's limit; the forecaster's own chance of this, stated with the estimate: 60%; the middle value is on the limit's open side.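

Compound 2 and compound 3 both end at a limit rather than a number, so no step can be read between them: the limit of < 20% in this assay, at which 3 of the 3 values shown sit.

The compounds shown leave open whether any change to the shared core gives a measurable number in this assay.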